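Fluoro for Methyl in a Level Pair

The source may hold more compounds than are shown below. What is called first, only, known or untested is meant among the compounds shown, and "the series" means these compounds.

Among the compounds with values here, in a functional assay on A549 cells (Homo sapiens) for cytotoxicity, read by MTT assay, with a stated time of 24 h (a lower number here means a stronger inhibitor, a higher number a weaker inhibitor), compound 1 (`C#CCn1c(=O)c(/C=C/C(=O)/C=C(O)/C=C/c2ccc(O)c(OC)c2)cc2ccccc21`) gives 21300 nM and compound 2 (`C#CCn1c(=O)c(/C=C/C(=O)/C=C(O)/C=C/c2ccc(O)c(OC)c2)cc2cc(C)ccc21`) gives 23900 nM as its reading, so compound 2 stands level with its only neighbour once the usual scatter of repeat measurements is allowed for. Compound 3 (`C#CCn1c(=O)c(/C=C/C(=O)/C=C(O)/C=C/c2ccc(O)c(OC)c2)cc2cc(F)ccc21`) has not yet been measured. It differs from compound 2 in one place, with fluoro in place of methyl on an aromatic carbon, meta to a fused ring and para to a fused ring (fluoro in place of methyl on an aromatic carbon). Within the data shown here, the one measured step that bears on this is methyl in place of hydrogen on that carbon (a 1.1-fold higher number from compound 1 to compound 2 (0.05 log units; within the scatter)), and it stays within the scatter. Among the measured compounds shown here, no fluoro compound has been measured yet, so the data suggest no direction, and no step beyond the scatter is expected in this assay here. The expected change is small (a 1.1-fold lower number from compound 2 to compound 3 (0.04 log units; within the scatter)). For compound 3 the estimate is (22000 nM), expected to fall between the bounds (12000 nM to 40000 nM).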

Compound 3, half-maximal inhibitory concentration: 40500 nM
Beside the measured number, compound 3's estimate is 1.8-fold (0.27 log units) below it, outside the stated range (above it).
By their numbers in this assay, from the lowest: compounds 1, 2 and 3 (each within the scatter of the next).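

In this assay, this aromatic carbon of the shared core has now carried hydrogen, methyl and fluoro, and the readings remain level: a 1.7-fold higher number from compound 2 to compound 3 (0.23 log units; within the scatter) and a 1.9-fold higher number from compound 1 to compound 3 (0.28 log units; within the scatter) both lie within the usual scatter of repeat measurements. Fluoro in place of either methyl or hydrogen at this position therefore gives no step that can be told apart from that scatter, so these three compounds show this carbon tolerating all three without a clear difference in the reading. No measurement is available that would explain these readings.

On these data alone, whether an amine, a methoxy group or a carboxylic acid on this same carbon would give a step beyond the scatter stays open. So does whether fluoro would read the same on another carbon of that ring.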